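Series notes: 2-methylprop-1-en-1-yl to isobutyl

A few compounds are considered here, and "the series" means these few. Any claim that something is new, unique, unknown or untested is made for them only; others in the source may bear on it.

Among the compounds with values here, the three measured members share one core and differ in the group on the saturated chain carbon bound to the aromatic nitrogen and in the amine-bearing side. In an assay on isolated protein for inhibition of aldehyde dehydrogenase 1A1 (Homo sapiens), read by spectrophotometry, tested at 10 uM (on this read-out higher numbers stand for more inhibition at the one concentration tested (going by the name of the read-out) and lower numbers for less inhibition), compound 2 `CC(C)=CCn1c(CN2CCN(C(=O)C3CC3)CC2)nc2ccccc21` gives 74.3%, the highest of the three numbers. Compound 1 `O=C(C1CC1)N1CCN(Cc2nc3ccccc3n2Cc2ccccc2C(F)(F)F)CC1` gives 56.3% in this assay, and compound 3 `CC(C)CCn1c(OC2CCN(C(=O)c3ccco3)CC2)nc2ccccc21` gives 30.8%. Within the data shown here, the one single-point step measured, a number 18 percentage points higher from compound 1 to compound 2 (beyond the scatter), shows that the group on this chain carbon moves the read-out beyond the scatter. Compound 3 carries an isopentyl group at that place but also a different linker and amide, so its value is only a second look at a saturated chain within a different frame.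

Compound 4 `CC(C)CCn1c(CN2CCN(C(=O)C3CC3)CC2)nc2ccccc21` is not yet measured. It differs from compound 2 as follows: isobutyl in place of 2-methylprop-1-en-1-yl on a saturated chain carbon bound to an aromatic nitrogen. Among the measured compounds shown here, the measured step bearing on it is a number 18 percentage points higher from compound 1 to compound 2 (beyond the scatter), which concerns a different pair of groups at the same place; no step isolates the loss of the double bond alone. For the measured compounds named here, compound 3, the only measured member with a saturated chain at that place, sits at 30.8%. For compound 4 a modest downward step is expected, a number 14.3 percentage points lower from compound 2 to compound 4 (beyond the scatter), and its value in this assay is estimated at 60%, within 40% to 78%.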

Compound 4, a percentage reported as inhibition, at one concentration (the size of the read-out at that concentration, not a potency): 70%
The estimate for compound 4 lay 10 percentage points below the measured number; the range from low to high includes it.
By their numbers in this assay, from the lowest: compound 3; then compound 1; then compounds 4 and 2 (each within the scatter of the next).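

In this assay, isobutyl in place of 2-methylprop-1-en-1-yl on a saturated chain carbon bound to an aromatic nitrogen gives a number 4.3 percentage points lower from compound 2 to compound 4 (within the scatter), so the two groups cannot be told apart at this place on this frame, and the one double bond outside aromatic rings that leaves is not required for the read-out to hold. Isobutyl in place of 2-(trifluoromethyl)phenyl at the same place gives a number 13.7 percentage points higher from compound 1 to compound 4 (beyond the scatter), which adds a second comparison to the step from compound 1 to compound 2. Compound 2 and compound 4, both with a group that has no ring, now each stand beyond the scatter from compound 1, though this rests on these three compounds only.

Going by these compounds, it stays open whether the number in this assay would be higher, lower or level with other groups at this place, such as a longer chain, a chain ending in an amine or a chain ending in a carboxylic acid. On these data alone, it also stays open whether isobutyl and 2-methylprop-1-en-1-yl would remain indistinguishable with the linker and amide of compound 3 in the frame. No measurement at hand accounts for either step.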